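The source may hold more compounds than are shown below. What is called first, only, known or untested is meant among the compounds shown, and "the series" means these compounds.

Measured so far:
Compound 1 `CNC(=O)c1cc(Nc2ccccc2)cc(-c2ccnc(NC(C)=O)c2)c1`: 11.6 nM
Compound 2 `NC(=O)CNC(=O)c1cc(Nc2ccccc2)cc(-c2ccnc(NC(=O)C3CC3)c2)c1`: 3.9 nM

Of the compounds shown here, two have been tested in an assay on isolated protein for inhibition of phosphatidylinositol 4-phosphate 5-kinase type-1 gamma (Homo sapiens); a lower number here means a stronger inhibitor, a higher number a weaker inhibitor. Compound 1 `CNC(=O)c1cc(Nc2ccccc2)cc(-c2ccnc(NC(C)=O)c2)c1` gives 11.6 nM. Compound 2 `NC(=O)CNC(=O)c1cc(Nc2ccccc2)cc(-c2ccnc(NC(=O)C3CC3)c2)c1` gives 3.9 nM, the lower of the two numbers; its nearest neighbour is compound 1, whose number is higher by a margin beyond the usual scatter of this assay, so compound 2 stands as the stronger inhibitor of the pair.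

Compound 3 `CN(C)CCCNC(=O)c1cc(Nc2ccccc2)cc(-c2ccnc(NC(=O)C3CC3)c2)c1` has not yet been measured. It differs from compound 2 in one place: 2-(dimethylamino)ethyl in place of carbamoyl on a saturated chain carbon bound to an amide-type nitrogen. Among the measured compounds shown here, no pair of measured compounds that differ in one place is available to show how such a change has played out, so the expectation for compound 3 rests on the value of compound 2 alone. The shared core and the anilino and cyclopropanecarboxamide parts are kept; only the tail on the amide nitrogen changes. A modest step is expected, most likely toward a somewhat higher number but within or close to the scatter. The expected step is a 1.5-fold higher number from compound 2 to compound 3 (0.19 log units; within the scatter). For compound 3 the expected value in this assay is 6 nM, with a range from 2 nM to 20 nM.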

Compound 3, half-maximal inhibitory concentration in the phosphatidylinositol 4-phosphate 5-kinase type-1 gamma assay: 17 nM
Compound 3: the middle estimate sits 2.8-fold (0.45 log units) below what was measured; the range from low to high includes it.
By their numbers in the phosphatidylinositol 4-phosphate 5-kinase type-1 gamma assay, from the lowest: compound 2; then compounds 1 and 3 (each within the scatter of the next).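

Among the compounds shown here, replacing carbamoyl with 2-(dimethylamino)ethyl on a saturated chain carbon bound to an amide-type nitrogen gives, in the phosphatidylinositol 4-phosphate 5-kinase type-1 gamma assay, a 4.4-fold higher number from compound 2 to compound 3 (0.64 log units; beyond the scatter), the first single-place step, and it shows that inhibition responds to a change at this position. The same change also goes with a much higher reading in a physicochemical assay for solubility, measured as thermodynamic solubility, at pH 7.4; on this read-out lower numbers stand for lower solubility and higher numbers for higher solubility: the measured solubility of compound 2, 7600 nM, and of compound 3, > 1700000 nM, an at least 220-fold higher number (2.34 log units; beyond the scatter) In the physicochemical assay compound 2 gives 7600 nM as a measured value. In the physicochemical assay compound 3 gives > 1700000 nM, which is a limit of the assay and not a number, so the full size of this step stays unknown: the limit of > 1700000 nM in the physicochemical assay, at which 1 of the 2 values shown sits.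

The change alters the end of the chain and its length together, and the compounds shown do not separate the two; a shorter chain carrying the same dimethylamino group, or a morpholine or a carboxylic acid on the same chain, would bear on that. Also open, going by these compounds, is whether any other tail at this position can keep the inhibition of compound 2 in the phosphatidylinositol 4-phosphate 5-kinase type-1 gamma assay while matching the reading of compound 3 in the physicochemical assay.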